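Aryl swap on the ethyl-linked arm of compound 3

The source may report more compounds than this note shows. Statements on the series, on what has been measured and on what is new or still open speak of the compounds shown alone.

Measured compounds in a functional assay on CHO cells for antagonist activity at Orexin/Hypocretin receptor type 1 (Homo sapiens), read by FLIPR and calcium flux; a higher number here means a weaker inhibitor, a lower number a stronger inhibitor:
compound 1 `CCc1nc(Cl)c2n1CCN([C@@H](C(=O)NC)c1ccccc1)[C@H]2COc1ccc(C(F)(F)F)cc1` gives 431 nM
compound 2 `CCc1nc(Cl)c2n1CCN([C@@H](C(=O)NC)c1ccccc1)[C@H]2COc1cccc(C(F)(F)F)c1` gives 312 nM
compound 3 `CNC(=O)[C@@H](c1ccccc1)N1CCn2c(C3CC3)nc(Cl)c2[C@@H]1CCc1ccc(C(F)(F)F)cc1` gives 30 nM

Compound 3 stands lowest of the three numbers in this assay; its gaps to compound 2 and to compound 1 both lie beyond the scatter. Going by the values given here, compounds 1 and 2 differ from compound 3 in more than one place (the core substituent and the linker to the aryl group), so no single step connects them to compound 3.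

Among the compounds with values here, the only step with one change is a 1.4-fold lower number from compound 1 to compound 2 (0.14 log units; within the scatter), an aryl swap on the oxygen-linked arm that left the number where it was.

Compound 4 `CNC(=O)[C@@H](c1ccccc1)N1CCn2c(C3CC3)nc(Cl)c2[C@@H]1CCc1ccc(OC(F)F)c(F)c1` differs from compound 3 as follows: 4-(difluoromethoxy)-3-fluorophenyl in place of 4-(trifluoromethyl)phenyl on a saturated chain carbon, two bonds along the chain from a saturated ring carbon. Within the data shown here, no measured step touches the ethyl-linked arm, and none exchanges a trifluoromethyl for a difluoromethoxy group together with an added fluorine. Among the measured compounds shown here, the one aryl-to-aryl step at hand, a 1.4-fold lower number from compound 1 to compound 2 (0.14 log units; within the scatter), stayed within the scatter, but it sits on a different arm of a core with a different substituent, so it carries little weight here.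

With nothing pointing firmly either way, compound 4 is expected near 45 nM, with a range from 15 nM to 150 nM. The expected step is a 1.5-fold higher number from compound 3 to compound 4 (0.18 log units; within the scatter), i.e. none beyond the scatter, with a wider range than usual to cover the untested change.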

Compound 4, half-maximal inhibitory concentration: 170 nM
Beside the measured number, compound 4's estimate is 3.8-fold (0.58 log units) below it; measured number above the stated range.
By their numbers in this assay, from the lowest: compound 3; then compounds 4, 2 and 1 (each within the scatter of the next, the first and the last beyond it).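

In this assay, the aryl group on the saturated chain carbon, two bonds along the chain from a saturated ring carbon, proves to matter: 4-(difluoromethoxy)-3-fluorophenyl in place of 4-(trifluoromethyl)phenyl gives a 5.7-fold higher number from compound 3 to compound 4 (0.75 log units; beyond the scatter). Going by these compounds alone, this is the first measured step on this arm, and the only other aryl swap, a 1.4-fold lower number from compound 1 to compound 2 (0.14 log units; within the scatter), sits on the oxygen-linked arm of a core with a different substituent, so the two steps say nothing about each other and the sensitivity seen here belongs to this arm alone. No evidence at hand bears on what lies behind this step.

The change is a composite one, with a difluoromethoxy group taking the place of trifluoromethyl, an oxygen and one more heavy atom entering, and a fluorine added to the ring, and no compound shown holds one of these features without the others, so the step cannot be assigned to either part. Also open, as far as these compounds go, is how this arm responds to a plain phenyl, a phenyl carrying a nitrile or an amine, or a longer chain to the aryl group.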